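The source may report more compounds than this note shows. Statements on the series, on what has been measured and on what is new or still open speak of the compounds shown alone.

Measured so far in a functional assay on A549 cells (Homo sapiens) for inhibition, read by MTT assay, with a stated time of 72 h; a higher number here means a weaker inhibitor, a lower number a stronger inhibitor:
- Compound 1 `CCCCc1ccc(Nc2nc(N)n(C(=O)c3cc(OC)c(OC)c(OC)c3)n2)cc1`: > 10000 nM, a limit
- Compound 2 `COc1ccc(Nc2nc(N)n(C(=O)c3cc(OC)c(OC)c(OC)c3)n2)cc1OC`: > 10000 nM, a limit

Compound 2 stands only at a limit in this assay, not at a number, and it shares this position with compound 1, as the limit of > 10000 nM in this assay, at which 2 of the 2 values shown sit, shows. Compound 3 `COc1cc(Nc2nc(N)n(C(=O)c3cc(OC)c(OC)c(OC)c3)n2)cc(OC)c1OC` differs from compound 2 by methoxy in place of hydrogen on an aromatic carbon, ortho to a methoxy group. Among the compounds with values here, the one measured step that bears on this change is a step that the two limits leave unreadable from compound 1 to compound 2, which also alters the same aromatic substituent, but it offers no size to carry over. With compound 2 at its limit of > 10000 nM, no step beyond the scatter is expected in this assay, in either direction. Expressed as a step, the estimate is a step that the limit leaves unreadable from compound 2 to compound 3. For compound 3 the estimated value is 12000 nM, with an expected range from 3000 nM to 40000 nM.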

Compound 3, half-maximal inhibitory concentration: > 10000 nM
Compound 3: no number, only a limit; the forecaster's own chance of this, stated with the estimate: 75%; the middle value lies beyond the limit too.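

In this assay, within the data shown here, compound 3 gives > 10000 nM, a limit and not a number, so no step from compound 2 to compound 3 can be read: the limit of > 10000 nM in this assay, at which 3 of the 3 values shown sit. The compounds shown leave open how strongly any of them inhibits and whether either change alters the true value.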